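This account rests on a few compounds, and the source may have more. Where it says the series, first, only, none or still open, it means among the compounds named here.

Measured so far:
- compound 1, `O=c1sc2ccccc2n1CCCCN1CCCCCC1`: 3.2 nM
- compound 2, `CCC(=O)c1ccc2c(c1)sc(=O)n2CCCN1CCCCCC1`: 3.7 nM

Both numbers come from an assay on cell membranes for displacement of a labelled ligand from Sigma non-opioid intracellular receptor 1 (Rattus norvegicus); on this read-out higher numbers stand for weaker inhibition and lower numbers for stronger inhibition. Compound 1 gives 3.2 nM and compound 2 gives 3.7 nM; compound 2 holds the higher of the two numbers, but the gap to compound 1 lies within the scatter, so the two values are to be read as the same.

Compound 3, `CCC(=O)c1ccc2c(c1)sc(=O)n2CCCCN1CCCCCC1`, has not yet been measured. It differs from compound 2 in one place: (azepan-1-yl)methyl in place of azepan-1-yl on a saturated chain carbon, three bonds along the chain from an aromatic nitrogen. In plain words, the saturated chain that joins the aromatic nitrogen of the shared core to the seven-membered ring grows by one carbon, so compound 3 carries the longer chain of compound 1 together with the propanoyl group of compound 2.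

Compound 1 already shows that the longer chain sits well with a number of 3.2 nM in this assay, and compound 2 shows that the propanoyl group sits well with 3.7 nM. For compound 3 the step is therefore expected to be small, a 1.2-fold lower number from compound 2 to compound 3 (0.09 log units; within the scatter), none beyond the scatter. The estimate for compound 3 in this assay is 3 nM, between 1 nM and 10 nM.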

Compound 3, inhibition constant: 10.3 nM
Estimate against measurement, compound 3: 3.4-fold (0.54 log units) below; measured number outside the range, above it.
By their numbers in this assay, from the lowest: compounds 1 and 2 (each within the scatter of the next); then compound 3.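

In this assay, adding one carbon to the saturated chain, so that azepan-1-yl becomes (azepan-1-yl)methyl, does matter when the propanoyl group is present: the change gives a 2.8-fold higher number from compound 2 to compound 3 (0.44 log units; beyond the scatter), which means weaker inhibition. Putting propanoyl in place of hydrogen on an aromatic carbon also weakens inhibition when the longer chain is present, giving a 3.2-fold higher number from compound 1 to compound 3 (0.51 log units; beyond the scatter), so the good numbers of the two parent compounds did not carry over to the compound that holds both features. Nothing available here explains this loss.

The compounds shown leave open whether the chain length has any effect on the shared core without the propanoyl group, since only the combination with propanoyl can be read here. They also leave open how the number in this assay would respond to a still longer chain, or to a smaller acetyl group in place of propanoyl, and either would show how closely these two parts of the molecule depend on each other.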